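Carboxyphenyl position on the second ring arrangement

The compounds below may be only part of what the source reports. "The series", "measured", "known", "first", "only" and "open" are said of these compounds alone.

Compound 3 `CC(C)c1onc(-c2c(Cl)cccc2Cl)c1COc1ccc2cc(-c3cccc(C(=O)O)c3)sc2c1` stands second highest of the three numbers in an assay on isolated protein for binding affinity to Bile acid receptor (Homo sapiens), read by FRET (on this read-out lower numbers stand for an effect already at smaller amounts and higher numbers for an effect only at larger amounts of compound), with 140 nM. Its nearest neighbour is compound 2 `CC(C)c1onc(-c2c(Cl)cccc2Cl)c1COc1ccc2sc(-c3ccc(C(=O)O)cc3)cc2c1` at 280 nM, within the scatter; furthest is compound 1 `CC(C)c1onc(-c2c(Cl)cccc2Cl)c1COc1ccc2sc(-c3cccc(C(=O)O)c3)cc2c1` at 55 nM, beyond it. Compound 4 `CC(C)c1onc(-c2c(Cl)cccc2Cl)c1COc1ccc2cc(-c3ccc(C(=O)O)cc3)sc2c1` differs from compound 3 only by 4-carboxyphenyl in place of 3-carboxyphenyl on an aromatic carbon. Going by the values given here, the one measured step bearing on this exchange is a 5.1-fold higher number from compound 1 to compound 2 (0.71 log units; beyond the scatter), the same swap on the other arrangement of the shared core. A comparable rise is therefore expected here: a 4.0-fold higher number from compound 3 to compound 4 (0.60 log units; beyond the scatter). The number for compound 4 in this assay is estimated at 560 nM, with a range from 250 nM to 1300 nM.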

Compound 4, half-maximal effective concentration: 200 nM
The estimate for compound 4 lay 2.8-fold (0.45 log units) above the measured number; measured number outside the range, below it.
By their numbers in this assay, from the lowest: compound 1; then compounds 3, 4 and 2 (each within the scatter of the next).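

In this assay, 4-carboxyphenyl in place of 3-carboxyphenyl next to the ring sulfur gives a 1.4-fold higher number from compound 3 to compound 4 (0.15 log units; within the scatter), so the two groups cannot be told apart on this core. The earlier pair alone suggested a clear penalty for this change, but its size depends on the core: the same change on two cores in this assay, a 5.1-fold higher number (0.71 log units; beyond the scatter) from compound 1 to compound 2 and a 1.4-fold higher number (0.15 log units; within the scatter) from compound 3 to compound 4, 3.6-fold (0.55 log units) apart, beyond the scatter of two such steps

Going by these compounds alone, only two cores carry this exchange, so no general rule for the position can be drawn. As far as these compounds go, whether the difference between the cores persists when a primary amide or a tetrazole replaces the carboxylic acid remains open.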